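Replacing the Methyl Group with a Second Fluorine

This account rests on a few compounds, and the source may have more. Where it says the series, first, only, none or still open, it means among the compounds named here.

Measured so far:
compound 1 `COc1ccc(F)c([C@H]2CC[C@H](COc3cccc([C@H](C4CC4)[C@@H](C)C(=O)O)c3)CC2)c1`, 2.2 nM
compound 2 `COc1ccc(F)c([C@H]2CC[C@H](COc3cccc([C@H](C4CC4)[C@H](F)C(=O)O)c3)CC2)c1`, 54 nM
compound 3 `COc1ccc(F)c([C@H]2CC[C@H](COc3cccc([C@H](C4CC4)[C@@](C)(F)C(=O)O)c3)CC2)c1`, 0.25 nM

In a functional assay on HEK293 cells for agonist activity at Free fatty acid receptor 1 (Homo sapiens), read by FLIPR and calcium flux (a higher number here means that more compound is needed for the effect, a lower number that less compound is needed), compound 3 gives the lowest number of the three: compound 1 sits at 2.2 nM and compound 2 at 54 nM. Compound 4 `COc1ccc(F)c([C@H]2CC[C@H](COc3cccc([C@H](C4CC4)C(F)(F)C(=O)O)c3)CC2)c1` is its unmeasured neighbour, differing by carboxy(difluoro)methyl in place of 1-carboxy-1-fluoroethyl on a saturated chain carbon bound to an aromatic carbon and a saturated ring carbon. For the measured compounds named here, two measured steps bear on this. Fluorine in place of hydrogen gave an 8.8-fold lower number from compound 1 to compound 3 (0.94 log units; beyond the scatter); methyl in place of hydrogen gave a 220-fold lower number from compound 2 to compound 3 (2.33 log units; beyond the scatter). Compound 4 keeps the fluorine of compound 3 but loses its methyl, so the large methyl step is the one undone, and a clearly higher number is expected, though not the full amount, since compound 2 to compound 4 resembles the fluorine step. Compound 4 is therefore estimated at 6 nM, ranging from 1.5 nM to 30 nM. This expected change is a 24-fold higher number from compound 3 to compound 4 (1.38 log units; beyond the scatter).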

Compound 4, half-maximal effective concentration: 16 nM
Compound 4: middle estimate off by 2.7-fold (0.43 log units), on the low side; low and high end bracket the measured number.
By their numbers in this assay, from the lowest: compound 3; then compound 1; then compound 4; then compound 2.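

Putting carboxy(difluoro)methyl in place of 1-carboxy-1-fluoroethyl gives a 64-fold higher number from compound 3 to compound 4 (1.81 log units; beyond the scatter) and shows that a second fluorine does not stand in for the methyl of compound 3. That fluorine still counts for something: adding it to the single-fluorine group gives a 3.4-fold lower number from compound 2 to compound 4 (0.53 log units; beyond the scatter) as the result. Against the 1-carboxyethyl group, however, the same difluoro group gives a 7.3-fold higher number from compound 1 to compound 4 (0.86 log units; beyond the scatter) as the outcome, so two fluorines do not match even the methyl and hydrogen pair. As far as these compounds go, what an ethyl group or a chlorine atom would do in place of the second fluorine stays open. Nothing shown explains why these steps differ.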